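The source may report more compounds than this note shows. Statements on the series, on what has been measured and on what is new or still open speak of the compounds shown alone.

Of the compounds shown here, three that share one core have been tested in an ADME assay on MT4 cells (Homo sapiens) for cytotoxicity, read by MTT assay, with a stated time of 4 days; on this read-out lower numbers stand for higher toxicity in this test and higher numbers for lower toxicity in this test. Compound 1 `Cc1ccc(NC(=O)CS(=O)(=O)c2nccc(Oc3c(C)cc(C#N)cc3C)n2)cc1C` gives 13900 nM. Compound 2 `COc1ccc(NC(=O)CS(=O)(=O)c2nccc(Oc3c(C)cc(C#N)cc3C)n2)cc1` gives 5110 nM. Compound 3 `Cc1cc(C#N)cc(C)c1Oc1ccnc(S(=O)(=O)CC(=O)Nc2ccc(Cl)c(Cl)c2)n1` gives 11700 nM. Among these three, compound 2 stands at the lowest number, so it is the most toxic of the set: the step to its nearest neighbour is a 2.3-fold higher number from compound 2 to compound 3 (0.36 log units; beyond the scatter), and the step from the furthest one is a 2.7-fold lower number from compound 1 to compound 2 (0.43 log units; beyond the scatter), both beyond the scatter. The step of a 1.2-fold lower number from compound 1 to compound 3 (0.07 log units; within the scatter) lies within the scatter.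

Compound 4 `Cc1cc(C#N)cc(C)c1Oc1ccnc(S(=O)(=O)CC(=O)Nc2ccc([N+](=O)[O-])cc2)n1` has not yet been measured in this assay. It differs from compound 2 in one place: nitro in place of methoxy on an aromatic carbon. Among the measured compounds shown here, none of the measured steps swaps a group at this place, since all three of them exchange the whole ring on the amide-type nitrogen, so the bearing they have is indirect. They show that the ring on the amide-type nitrogen moves the number in this assay by modest amounts at most, and that compound 2 sits at the toxic end. A modest move back toward the other two compounds is therefore expected, giving a 1.6-fold higher number from compound 2 to compound 4 (0.19 log units; within the scatter), though a number close to compound 2 remains well possible. Compound 4 is thus estimated at 8000 nM, within a range of 3500 nM to 18000 nM.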

Compound 4, half-maximal cytotoxic concentration: 59600 nM
Compound 4: the middle estimate sits 7.5-fold (0.87 log units) below what was measured, and the stated range ends below it.
By their numbers in this assay, from the lowest: compound 2; then compounds 3 and 1 (each within the scatter of the next); then compound 4.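

Swapping a single group at this place, methoxy to nitro on an aromatic carbon para to a large group, gives the largest move seen so far in this assay, with a 12-fold higher number from compound 2 to compound 4 (1.07 log units; beyond the scatter). The new compound also stands clear of the other two, with a 5.1-fold higher number from compound 3 to compound 4 (0.71 log units; beyond the scatter) and a 4.3-fold higher number from compound 1 to compound 4 (0.63 log units; beyond the scatter), both beyond the scatter, so compound 4 has the highest number of the four and is the least toxic in this test. The earlier compounds shown here, which differ by whole-ring exchanges, showed only modest moves, whereas this result shows that one group on this ring can shift the number far more and that the ring's effect on toxicity in this test is not limited to small steps.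

No accompanying data bear on what lies behind this large shift. Going by these compounds, whether an amine or a carboxylic acid at this place would give a number close to compound 4 or close to compound 2 stays open, as does whether nitro would have the same effect with a second group, such as chloro or methyl, on the same ring.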